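Amide series on the hexafluoro-carbinol naphthalene core

The source may hold more compounds than are shown below. What is called first, only, known or untested is meant among the compounds shown, and "the series" means these compounds.

Measured compounds:
compound 1 `O=C(Nc1ccc(Cl)cc1)Nc1c(C(O)(C(F)(F)F)C(F)(F)F)ccc2ccccc12`: 276 nM
compound 2 `O=C(Nc1c(C(O)(C(F)(F)F)C(F)(F)F)ccc2ccccc12)c1cccc(C(F)(F)F)c1`: 84 nM

Going by the values given here, in an assay on LtK cells with ATP-sensitive inward rectifier potassium channel 11 (Homo sapiens) as the target (a lower number here means that less compound is needed, a higher number that more compound is needed for the effect), compound 2 gives 84 nM, the lowest of the two numbers so far. Among the compounds with values here, compound 1 gives 276 nM, and the one measured step is a 3.3-fold lower number from compound 1 to compound 2 (0.52 log units; beyond the scatter), which concerns an exchange of the whole group on the carbonyl carbon and also removes an amide-type nitrogen. Compound 3 `O=C(Nc1c(C(O)(C(F)(F)F)C(F)(F)F)ccc2ccccc12)c1cccs1` differs from compound 2 as follows: thiophen-2-yl in place of 3-(trifluoromethyl)phenyl on a carbonyl carbon. Within the data shown here, no measured step exchanges one aromatic ring on the carbonyl carbon for another, so the single known step only shows that this position can move the number well beyond the scatter. Among the measured compounds shown here, with no direct precedent the expectation for compound 3 is a modest rise in the number, estimated as a 2.4-fold higher number from compound 2 to compound 3 (0.38 log units; beyond the scatter). The value of compound 3 is thus estimated at 200 nM, with a range from 70 nM to 600 nM.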

Compound 3, half-maximal effective concentration: 12 nM
Beside the measured number, compound 3's estimate is 17-fold (1.22 log units) above it; the whole stated range lies above it.
By their numbers in this assay, from the lowest: compound 3; then compound 2; then compound 1.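

In this assay, the exchange of one aromatic ring for another on the carbonyl carbon gives a 7.0-fold lower number from compound 2 to compound 3 (0.85 log units; beyond the scatter), so the choice of ring alone moves the number beyond the scatter, with the amide-type nitrogen kept in place. Thiophen-2-yl also gives a 23-fold lower number from compound 1 to compound 3 (1.36 log units; beyond the scatter), and with fewer heavy atoms than 3-(trifluoromethyl)phenyl, the smaller group here carries the lowest number of the three. No available evidence accounts for either step.

The compounds shown do not separate the contributions of the ring sulfur, the five-membered ring and the loss of the trifluoromethyl group. Also open, on these data alone, is where an unsubstituted phenyl, a furan-2-yl or a thiophen-2-yl bearing a carboxylic acid would fall on the carbonyl carbon.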